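Carboxylic acid in place of a propoxy chain

The source may report more compounds than this note shows. Statements on the series, on what has been measured and on what is new or still open speak of the compounds shown alone.

Measured compounds:
compound 1, `Cc1cccnc1-c1ccc(C(=O)Nc2ccc(C(C)C)cc2)cc1`, 73 nM
compound 2, `CCCOc1cccnc1-c1ccc(C(=O)Nc2ccc(C(C)(C)C)cc2)cc1`, 62 nM

Both measured compounds share the same core and were tested in a functional assay for antagonist activity at transient receptor potential cation channel subfamily V member 1 (Homo sapiens), read by FLIPR; a lower number here means a stronger inhibitor, a higher number a weaker inhibitor. In this assay compound 1 gives 73 nM, and compound 2 gives 62 nM; the gap between the two values lies within the usual scatter of repeated measurements, so neither can be called the stronger of the pair.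

The next compound, compound 3 with structure `CC(C)(C)c1ccc(NC(=O)c2ccc(-c3ncccc3C(=O)O)cc2)cc1`, differs from compound 2 in one place: carboxy in place of propoxy on an aromatic carbon. In words, a carboxy takes the place of a propoxy on an aromatic carbon, two atoms from the ring nitrogen and ortho to a large group.

Within the data shown here, no step between measured compounds of this kind is available, so nothing here shows how such a change moves the number. The expectation for compound 3 is nevertheless a clearly weaker inhibitor, with a 13-fold higher number from compound 2 to compound 3 (1.11 log units; beyond the scatter) as the estimated step, a move well beyond the scatter toward a higher number. Compound 3 is therefore expected to give 800 nM, with a plausible range from 200 nM to 5000 nM.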

Compound 3, half-maximal inhibitory concentration: > 4000 nM
Compound 3: only a limit was reported (the forecaster's own chance of this, stated with the estimate: 25%); at least 5.0-fold (0.69 log units) between middle value and limit.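

Among these compounds, compound 3 gives the first step in this set that changes one group and nothing else at this position, on an aromatic carbon two atoms from the ring nitrogen and ortho to a large group. In this assay compound 3 gives > 4000 nM, which is a limit of the assay and not a number. Exchanging the propoxy for a carboxy gives an at least 64-fold higher number from compound 2 to compound 3 (1.80 log units; beyond the scatter), so this position does not tolerate every group, and the true size of the loss stays unknown, as the step rests on a limit: the limit of > 4000 nM in this assay, at which 1 of the 3 values shown sits.

The compounds shown do not tell whether the large step comes from losing the propoxy chain or from gaining the carboxy, and a methyl ester or a primary amide at this position would help separate those two readings. Going by these compounds, an ethoxy group or a longer alkoxy chain in the same place would show how closely the value follows the length of the chain, while the reason for the loss remains open.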